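The source may report more compounds than this note shows. Statements on the series, on what has been measured and on what is new or still open speak of the compounds shown alone.

Measured compounds in an ADME assay on microsomes from liver (Homo sapiens) for metabolic stability; on this read-out higher numbers stand for fast clearance and lower numbers for slow clearance:
- compound 1, `O=C(Nc1ccnnc1)c1cc(N2CCC(CO)CC2)ccc1OCc1ccccc1`: 1 mL.min-1.g-1
- compound 2, `O=C(Nc1ccnnc1)c1cc(N2CCC(O)CC2)ccc1OCc1ccccc1`: 0.6 mL.min-1.g-1
- compound 3, `CN1CCN(c2ccc(OCc3ccccc3)c(C(=O)Nc3ccnnc3)c2)CC1`: 1.6 mL.min-1.g-1

On the numbers shown, compound 1 has compound 2 on one side and compound 3 on the other, yet neither gap is meaningful: a 1.7-fold lower number from compound 1 to compound 2 (0.22 log units; within the scatter) and a 1.6-fold higher number from compound 1 to compound 3 (0.20 log units; within the scatter) both fall within the scatter. Among the compounds with values here, the only step that stands out is a 2.7-fold higher number from compound 2 to compound 3 (0.43 log units; beyond the scatter), and that one is modest.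

Compound 4, `C[C@@H]1CN(c2ccc(OCc3ccccc3)c(C(=O)Nc3ccnnc3)c2)C[C@H](C)O1`, is not yet measured in this assay. It differs from compound 1 in one place: 2,6-dimethylmorpholin-4-yl in place of 4-(hydroxymethyl)piperidin-1-yl on an aromatic carbon. Within the data shown here, the nearest precedent is the change from compound 1 to compound 3, where a different ring without a hydroxy group also replaced the 4-(hydroxymethyl)piperidin-1-yl group and gave a 1.6-fold higher number from compound 1 to compound 3 (0.20 log units; within the scatter). Among the measured compounds shown here, compound 2, which keeps a hydroxy group, gives 0.6 mL.min-1.g-1, and the move from it to compound 3 is the only step here beyond the scatter.

Taken together, a small rise in clearance is expected for compound 4, roughly a 1.8-fold higher number from compound 1 to compound 4 (0.26 log units; within the scatter), though a result within the scatter of compound 1 would not surprise. The estimate for compound 4 in this assay is 1.8 mL.min-1.g-1, with a range from 0.8 mL.min-1.g-1 to 4 mL.min-1.g-1.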

Compound 4, intrinsic clearance in microsomes: 2.2 mL.min-1.g-1
The estimate for compound 4 lay 1.2-fold (0.09 log units) below the measured number; the measured number falls inside the stated range.
By their numbers in this assay, from the lowest: compounds 2, 1, 3 and 4 (each within the scatter of the next, the first and the last beyond it).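

In this assay, 2,6-dimethylmorpholin-4-yl on this aromatic carbon, para to a benzyloxy group, gives a 2.2-fold higher number from compound 1 to compound 4 (0.34 log units; beyond the scatter), so replacing 4-(hydroxymethyl)piperidin-1-yl here can produce a step beyond the scatter, which 4-methylpiperazin-1-yl did not do with a 1.6-fold higher number from compound 1 to compound 3 (0.20 log units; within the scatter). The two entering rings without a hydroxy group are not separated, with a 1.4-fold higher number from compound 3 to compound 4 (0.14 log units; within the scatter), while compound 2 stands apart from both, with a 2.7-fold higher number from compound 2 to compound 3 (0.43 log units; beyond the scatter) and a 3.7-fold higher number from compound 2 to compound 4 (0.56 log units; beyond the scatter); compound 1 keeps a hydroxy group yet lies within the scatter of compound 3, so the presence of that group does not sort the series on its own. Nothing available accounts for these steps.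

The compounds shown leave open whether the step to compound 4 goes with the methyl groups, the ring oxygen or the loss of the hydroxy group, a question that plain morpholin-4-yl and 4-(hydroxymethyl)piperidin-1-yl's amine analogue, 4-(aminomethyl)piperidin-1-yl, would bear on. They also leave open how the other stereoisomers of 2,6-dimethylmorpholin-4-yl compare at this position.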